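Pyridinyl ring positions on a shared dienone core

A few compounds are considered here, and "the series" means these few. Any claim that something is new, unique, unknown or untested is made for them only; others in the source may bear on it.

Measured compounds in a functional assay on QGY-7703 cells (Homo sapiens) for cytotoxicity, read by MTT assay, with a stated time of 24 h; a lower number here means a stronger inhibitor, a higher number a weaker inhibitor:
Compound 1 `COc1cc(/C=C2\CN(C)C/C(=C\c3cccnc3)C2=O)cc(OC)c1`: 7900 nM
Compound 2 `COc1ccc(/C=C2\CN(C)C/C(=C\c3cccnc3)C2=O)c(OC)c1OC`: 2630 nM
Compound 3 `COc1cc(/C=C2\CN(C)C/C(=C\c3ccncc3)C2=O)cc(OC)c1`: 8400 nM

Of the compounds shown here, three have been measured in this assay. Compound 1 gives 7900 nM, and compound 3 gives 8400 nM. The change between them is pyridin-4-yl in place of pyridin-3-yl on a double-bonded chain carbon bound to a double-bonded ring carbon and the step it made was a 1.1-fold higher number from compound 1 to compound 3 (0.03 log units; within the scatter). Compound 2 gives 2630 nM, the lowest number of the three and beyond the scatter from both of the others. The difference between the core of compound 2 and the core of compound 1 is not broken down here.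

Compound 4 `COc1ccc(/C=C2\CN(C)C/C(=C\c3ccncc3)C2=O)c(OC)c1OC` has not yet been measured. It differs from compound 2 by pyridin-4-yl in place of pyridin-3-yl on a double-bonded chain carbon bound to a double-bonded ring carbon, which is the same change already made from compound 1 to compound 3. Since the step from compound 1 to compound 3 fell within the scatter, the step from compound 2 to compound 4 is expected to be a 1.1-fold higher number from compound 2 to compound 4 (0.03 log units; within the scatter). Compound 4 is therefore estimated to give about 2800 nM in this assay, with a likely range from 1400 nM to 5600 nM.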

Compound 4, half-maximal inhibitory concentration: 8350 nM
For compound 4 the middle estimate is 3.0-fold (0.47 log units) below the measured one; the whole stated range lies below it.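

In this assay, pyridin-4-yl in place of pyridin-3-yl on the core of compound 2 gave a 3.2-fold higher number from compound 2 to compound 4 (0.50 log units; beyond the scatter). Among the compounds shown here, the size of this change therefore depended on the core carrying it, and the step measured on one core did not predict the step on the other: the same change on two cores in this assay, a 1.1-fold higher number (0.03 log units; within the scatter) from compound 1 to compound 3 and a 3.2-fold higher number (0.50 log units; beyond the scatter) from compound 2 to compound 4, 3.0-fold (0.48 log units) apart, beyond the scatter of two such steps This rests on a single pair of steps, so it shows only that the change did not transfer between these two cores; it does not show which part of the cores accounts for the gap, or how the change would behave on any further core.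

The compounds shown carry only pyridin-3-yl and pyridin-4-yl at this place, leaving open whether pyridin-2-yl or a plain phenyl group would also give steps that depend on the core. They also leave open what a hydroxyl group in place of a methoxy group on either core would do to the step.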